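The source may report more compounds than this note shows. Statements on the series, on what has been measured and on what is new or still open speak of the compounds shown alone.

Compound 2 `CCn1c(C(=O)N[C@@H](CC(=O)OC)C(=O)OC)ccc1C(CC)(CC)c1ccc(OCS(=O)(=O)c2ccccc2)c(C)c1` carries a 1,2-bis(methoxycarbonyl)ethyl group on an amide-type nitrogen. In a functional assay on MCF7 cells (Homo sapiens) for antiproliferative activity, read by MTT assay, with a stated time of 24 h (on this read-out higher numbers stand for weaker inhibition and lower numbers for stronger inhibition), compound 2 gives only a limit, > 50000 nM. Compound 1 `CCn1c(C(=O)N[C@H](C)C(=O)OC)ccc1C(CC)(CC)c1ccc(OCS(=O)(=O)c2ccccc2)c(C)c1` likewise gives only a limit in this assay, > 50000 nM. Compound 3 `CCn1c(C(=O)N[C@H](C)C(=O)O)ccc1C(CC)(CC)c1ccc(OCS(=O)(=O)c2ccccc2)c(C)c1` also gives only a limit there, > 50000 nM. Because all three values sit at the limit of > 50000 nM in this assay, at which 3 of the 3 values shown sit, the steps a step that the two limits leave unreadable from compound 1 to compound 2 and a step that the two limits leave unreadable from compound 2 to compound 3 have no readable size, and neither points in any direction. Compound 4 `CCn1c(C(=O)N[C@H](C(=O)O)C(C)C)ccc1C(CC)(CC)c1ccc(OCS(=O)(=O)c2ccccc2)c(C)c1` differs from compound 2 by 1-carboxy-2-methylpropyl in place of 1,2-bis(methoxycarbonyl)ethyl on an amide-type nitrogen. Going by the values given here, since every variation at this position so far has given only a limit in this assay, compound 4 is expected to do the same. Compound 4 is therefore estimated at 80000 nM, within 30000 nM to 300000 nM. That estimate would mean a step that the limit leaves unreadable from compound 2 to compound 4, which cannot be read against a limit.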

Compound 4, half-maximal inhibitory concentration: 24500 nM
Compound 4: middle estimate off by 3.3-fold (0.51 log units), on the high side; the whole stated range lies above it.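

In this assay, compound 4 is the first compound at this position to give a number rather than a limit, while the others remain at that limit: the limit of > 50000 nM in this assay, at which 3 of the 4 values shown sit.

The change therefore reads as an at least 2.0-fold lower number from compound 2 to compound 4 (0.30 log units; that floor lies within the scatter), as an at least 2.0-fold lower number from compound 3 to compound 4 (0.30 log units; that floor lies within the scatter) and as an at least 2.0-fold lower number from compound 1 to compound 4 (0.30 log units; that floor lies within the scatter). Going by these compounds, each of these is only a floor, so the true size of the step remains unknown.

The compounds shown leave open how far a longer chain, a phenyl group or an amine in place of 1-carboxy-2-methylpropyl on an amide-type nitrogen would move the number.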